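The compounds below may be only part of what the source reports. "The series", "measured", "known", "first", "only" and "open" are said of these compounds alone.

Compound 3 `CC(C)(N)C(=O)N[C@@H]1CCc2ccccc2N(Cc2ccc(-c3ccccc3CNC(=O)NC3CC3)cc2)C1=O` gives 45 nM in a functional assay (Pituitary gland cell) with Rattus norvegicus as the target (on this read-out lower numbers stand for an effect already at smaller amounts and higher numbers for an effect only at larger amounts of compound), the second highest of the three numbers recorded: compound 1 `CNC(=O)NCc1ccccc1-c1ccc(CN2C(=O)[C@H](NC(=O)C(C)(C)N)CCc3ccccc32)cc1` gives 1 nM and compound 2 `CC(C)NC(=O)NCc1ccccc1-c1ccc(CN2C(=O)[C@H](NC(=O)C(C)(C)N)CCc3ccccc32)cc1` gives 270 nM. Compound 4 `CC(C)(N)C(=O)N[C@@H]1CCc2ccccc2N(Cc2ccc(-c3ccccc3-c3nn[nH]n3)cc2)C1=O` differs from compound 3 by 2H-tetrazol-5-yl in place of ((cyclopropylcarbamoyl)amino)methyl on an aromatic carbon. Within the data shown here, none of the measured steps makes this exchange; all three vary only the group on the amide-type nitrogen, and there the changes were large, with a 270-fold higher number from compound 1 to compound 2 (2.43 log units; beyond the scatter) and a 45-fold higher number from compound 1 to compound 3 (1.65 log units; beyond the scatter), while a 6.0-fold lower number from compound 2 to compound 3 (0.78 log units; beyond the scatter). Since that part of the molecule proved sensitive, compound 4 is expected to move to a higher number, with a 6.7-fold higher number from compound 3 to compound 4 (0.82 log units; beyond the scatter) as the estimated step. For compound 4 the estimate is 300 nM, within 20 nM to 5000 nM.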

Compound 4, concentration for half-maximal effect: 30 nM
Compound 4: middle estimate off by 10-fold (1.00 log units), on the high side, and the stated range covers the measured number.
By their numbers in this assay, from the lowest: compound 1; then compounds 4 and 3 (each within the scatter of the next); then compound 2.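

In this assay, 2H-tetrazol-5-yl on this aromatic carbon gives a 1.5-fold lower number from compound 3 to compound 4 (0.18 log units; within the scatter), so that group and ((cyclopropylcarbamoyl)amino)methyl cannot be told apart here, although they share neither ring nor chain. Set against the other two side chains, the same group gives a 9.0-fold lower number from compound 2 to compound 4 (0.95 log units; beyond the scatter) and a 30-fold higher number from compound 1 to compound 4 (1.48 log units; beyond the scatter), so a five-membered aromatic ring with 4 hetero atoms is accepted at this place but does not reach the number of the methyl compound. No evidence on the reason for this result is available.

The compounds shown leave open whether a carboxylic acid on this aromatic carbon would give a number close to that of compound 4. They also leave open whether an ethyl group on the amide-type nitrogen would fall nearer compound 1 or compound 3.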